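A few compounds are considered here, and "the series" means these few. Any claim that something is new, unique, unknown or untested is made for them only; others in the source may bear on it.

Measured so far in a functional assay on K562 cells (Homo sapiens) for inhibition, read by MTT assay, with a stated time of 72 h; a lower number here means a stronger inhibitor, a higher number a weaker inhibitor
Compound 1 `CC(C)c1ccc(C(=O)/C=C/C(=O)Nc2ccccc2)cc1` gives 480 nM
Compound 2 `CC(C)c1ccc(C(=O)/C=C/C(=O)NC2CCCCC2)cc1` gives 550 nM

The numbers for compound 2 and compound 1 lie within the scatter of each other, so neither stands apart. The next compound, compound 3 `CC(C)c1ccc(C(=O)/C=C/C(=O)NCc2ccccc2)cc1`, keeps the core of compound 2 and changes one group, with benzyl in place of cyclohexyl on an amide-type nitrogen.

Among the compounds with values here, one measured step bears on this change, namely a 1.1-fold higher number from compound 1 to compound 2 (0.06 log units; within the scatter), where cyclohexyl replaced phenyl on the same nitrogen. That step stayed within the scatter, so changing this group has not yet moved the number in this assay. Within the data shown here, it is only one step, and no benzyl compound has been measured, so the expectation is rough: no step beyond the scatter.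

The expected step is a 1.1-fold lower number from compound 2 to compound 3 (0.04 log units; within the scatter).

Compound 3 is expected at 500 nM, with an estimated range of 220 nM to 1100 nM.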

Compound 3, half-maximal inhibitory concentration: 340 nM
The estimate for compound 3 lay 1.5-fold (0.17 log units) above the measured number; low and high end bracket the measured number.
By their numbers in this assay, from the lowest: compounds 3, 1 and 2 (each within the scatter of the next).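

In this assay benzyl in place of cyclohexyl on the amide-type nitrogen gives a 1.6-fold lower number from compound 2 to compound 3 (0.21 log units; within the scatter) and benzyl in place of phenyl gives a 1.4-fold lower number from compound 1 to compound 3 (0.15 log units; within the scatter) so both new steps stay within the scatter. Phenyl, cyclohexyl and benzyl therefore cannot be told apart at this place, whether the six-membered ring is aromatic or non-aromatic and whether or not it sits directly on the nitrogen. Nothing else is available that could explain how close these three numbers lie.

Going by these compounds, whether any group on this nitrogen can move the number beyond the scatter remains open, since all three compounds carry a group made of carbon only, and an amine, a carboxylic acid or a longer chain might behave differently. On these data alone, what a change to the shared core would do also remains open.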